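This account rests on a few compounds, and the source may have more. Where it says the series, first, only, none or still open, it means among the compounds named here.

For the measured compounds named here, compound 3 `CS(=O)(=O)NCCNC(=O)CN1CN(c2ccccc2)C2(CCN(C(=O)c3ccc(C4CCCCC4)cc3)CC2)C1=O` is the compound with the lowest number of the three measured so far in an assay on HEK293 cells for displacement of a labelled ligand from NPC1-like intracellular cholesterol transporter 1 (Homo sapiens) (a higher number here means a weaker inhibitor, a lower number a stronger inhibitor), and both of its neighbours lie beyond the scatter: compound 2 `O=C(CN1CN(c2ccccc2)C2(CCN(C(=O)c3ccc(C4CCCCC4)cc3)CC2)C1=O)NCO` gives 8300 nM, and compound 1 `COC(=O)CCNC(=O)CN1CN(c2ccccc2)C2(CCN(C(=O)c3ccc(C4CCCCC4)cc3)CC2)C1=O` gives 12900 nM, while compound 3 itself gives 2100 nM. Compound 4 `NCCNC(=O)CN1CN(c2ccccc2)C2(CCN(C(=O)c3ccc(C4CCCCC4)cc3)CC2)C1=O` has not yet been measured. It differs from compound 3 in one place: hydrogen in place of methylsulfonyl on an amine nitrogen.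

Going by the values given here, two measured steps bear on this change, since both end in compound 3 and both bring the methanesulfonamido group in. The step of a 6.1-fold lower number from compound 1 to compound 3 (0.79 log units; beyond the scatter) and the step of a 4.0-fold lower number from compound 2 to compound 3 (0.60 log units; beyond the scatter) each lowered the number by a modest amount. Among the compounds with values here, compound 4 removes the methylsulfonyl again, keeping only the amine, so the expectation is that the number rises back by a comparable modest amount, toward where compound 1 and compound 2 stand, though a bare amino group has no measured precedent here and the step could also stay within the scatter. Compound 4 is therefore estimated at 5500 nM in this assay, with a range from 1800 nM to 16000 nM, meaning an expected step of a 2.6-fold higher number from compound 3 to compound 4 (0.42 log units; beyond the scatter).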

Compound 4, half-maximal inhibitory concentration: 3800 nM
Compound 4: the middle estimate sits 1.4-fold (0.16 log units) above what was measured; the measured number falls inside the stated range.
By their numbers in this assay, from the lowest: compounds 3 and 4 (each within the scatter of the next); then compounds 2 and 1 (each within the scatter of the next).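

In this assay, removing the methylsulfonyl from the amine nitrogen gives a 1.8-fold higher number from compound 3 to compound 4 (0.26 log units; within the scatter), so the four heavy atoms of that group are not needed to keep the number in the range of compound 3. The plain 2-aminoethyl chain also keeps a measurable lead over the two earlier end groups, with a 2.2-fold lower number from compound 2 to compound 4 (0.34 log units; beyond the scatter) and a 3.4-fold lower number from compound 1 to compound 4 (0.53 log units; beyond the scatter). An amine nitrogen at this chain end, with or without the methylsulfonyl, therefore goes with a lower number than the hydroxy of compound 2 or the methoxycarbonyl of compound 1, but no measurement shown explains why these end groups differ.

From the compounds shown here alone, it remains open whether a carboxylic acid, a dimethylamino group or a longer chain ending in an amine would fall with compound 3 and compound 4 or with compound 1 and compound 2. Going by these compounds, all four compounds also share one core, so it is equally open whether the same change would give a similar step on a different group in place of the 4-cyclohexylbenzoyl part.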